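Aryl swap on a shared core in DU-145 growth inhibition

The source may report more compounds than this note shows. Statements on the series, on what has been measured and on what is new or still open speak of the compounds shown alone.

Measured so far:
compound 1, `CN(C)c1ccc(/C=C(/SCc2ccc(Cl)cc2)C(=O)c2ccc(Br)cc2)cc1`, 10000 nM
compound 2, `O=C(/C(=C\c1ccc(O)cc1O)Sc1ccccc1Br)c1ccc(Br)cc1`, 50000 nM

In a functional assay on DU-145 cells (Homo sapiens) for inhibition, read by trypan blue exclusion, with a stated time of 96 h (on this read-out higher numbers stand for weaker inhibition of growth and lower numbers for stronger inhibition of growth), compound 2 gives 50000 nM, the highest of the two numbers. Its nearest neighbour is compound 1, which gives 10000 nM, a gap beyond the scatter. Compound 3, `CN(C)c1ccc(/C=C(/Sc2ccccc2Br)C(=O)c2ccc(Br)cc2)cc1`, differs from compound 2 in one place: 4-(dimethylamino)phenyl in place of 2,4-dihydroxyphenyl on a double-bonded chain carbon bound to a double-bonded chain carbon. Compound 3 therefore carries the 4-(dimethylamino)phenyl of compound 1. Among the measured compounds shown here, no measured pair isolates this change. Because compound 1 gives 10000 nM with that group, a step from compound 2 toward stronger inhibition is expected, a 3.3-fold lower number from compound 2 to compound 3 (0.52 log units; beyond the scatter). Compound 3 is expected at 15000 nM, within 5000 nM to 50000 nM.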

Compound 3, concentration for 50% growth inhibition: > 100000 nM
Compound 3 gave a limit, no number (the forecaster's own chance of this, stated with the estimate: 15%); middle value at least 6.6-fold (0.82 log units) from the limit.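

Compound 3 stands at > 100000 nM in this assay, which is a limit of the assay and not a number. With 4-(dimethylamino)phenyl held fixed, 2-bromophenyl in place of 4-chlorobenzyl on a sulfur gives an at least 10-fold higher number from compound 1 to compound 3 (1.00 log units; beyond the scatter), so the group on sulfur clearly matters. 4-(Dimethylamino)phenyl in place of 2,4-dihydroxyphenyl gives an at least 2.0-fold higher number from compound 2 to compound 3 (0.30 log units; that floor lies within the scatter), so with 2-bromophenyl on sulfur this swap brings no stronger inhibition.

The compounds shown leave open how 2,4-dihydroxyphenyl behaves with 4-chlorobenzyl on sulfur, and whether a primary amine in place of the dimethylamino group would change growth inhibition.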